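The source may report more compounds than this note shows. Statements on the series, on what has been measured and on what is new or still open speak of the compounds shown alone.

Compound 1 `C=C(CC)C(=O)c1ccc(OCc2nc(-c3ccc4ccccc4c3)cs2)c(C)c1C`, compound 2 `C=C(C)C(=O)c1ccc(OCc2nc(-c3ccc(C(F)(F)F)cc3)cs2)c(C)c1C` and compound 3 `C=C(CC)C(=O)c1ccc(OCc2nc(-c3ccc([N+](=O)[O-])cc3)cs2)cc1Cl` share a core and differ in the groups attached to it. In an assay on HL-60 cells for inhibition of glutathione S-transferase P (Homo sapiens), read by spectrophotometry, tested at 5 uM (a higher number here means more inhibition at the concentration tested (going by the name of the read-out), a lower number less inhibition), compound 1 gives 0%, compound 2 gives 3.6%, and compound 3 gives 10.2%. Compound 3 thus holds the highest of the three numbers, but its gap to compound 2 lies within the usual scatter, so the two cannot be told apart; only its gap to compound 1 lies beyond the scatter.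

Compound 4 `C=C(CC)C(=O)c1ccc(OCc2nc(-c3ccc(C(F)(F)F)cc3)cs2)cc1Cl` has not yet been measured. It differs from compound 3 in one place: trifluoromethyl in place of nitro on an aromatic carbon. Going by the values given here, no measured pair shows this change by itself, so its effect has to be judged from the numbers above. Compound 2, which also carries a trifluoromethyl at this place but differs elsewhere, gives 3.6%, a number that sits within the scatter of compound 3. On that basis no step beyond the scatter is expected in this assay from compound 3 to compound 4, the expected step being a number 5.2 percentage points lower from compound 3 to compound 4 (within the scatter). For compound 4 the estimate in this assay is 5%, with a range from 0% to 15%.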

Compound 4, a percentage reported as inhibition, at one concentration (the size of the read-out at that concentration, not a potency): 19.7%
Compound 4: middle estimate off by 14.7 percentage points, on the low side; the whole stated range lies below it.
By their numbers in this assay, from the lowest: compounds 1, 2, 3 and 4 (each within the scatter of the next, the first and the last beyond it).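

In this assay, going by these compounds alone, the change from 4-nitrophenyl to 4-(trifluoromethyl)phenyl can now be read by itself for the first time, with everything else in the molecule held constant, and it amounts to a number 9.5 percentage points higher from compound 3 to compound 4 (within the scatter). At this place, para to a large group, the two groups therefore cannot be told apart, even though the swap removes the nitro group with its hydrogen-bond acceptors and brings in a trifluoromethyl group that has none. No measurement at hand explains this outcome.

As far as these compounds go, this is a single pair at a single concentration, so it remains open whether the same swap would give a similar step on the differently substituted core of compound 1 or compound 2, and the numbers say nothing about potency. From the compounds shown here alone, it is also open whether a quite different group at this place, such as an amine, a carboxylic acid, a methoxy group or a longer alkyl chain, would move the number beyond the usual scatter of the assay.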